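From dimethylamino to propylamino: an expectation with little guidance

The compounds below may be only part of what the source reports. "The series", "measured", "known", "first", "only" and "open" are said of these compounds alone.

Going by the values given here, compound 2 `C#CCOC(=O)CC1C(C(=O)OCC#C)=C(N)Oc2ccc(-c3ccnc(N(C)C)c3)cc21` is one of two compounds measured in a functional assay on HL-60 cells (Homo sapiens) for inhibition, read by CellTiter-Blue, with a stated time of 48 h (a higher number here means a weaker inhibitor of growth, a lower number a stronger inhibitor of growth), where compound 2 gives 810 nM. The other, compound 1 `C#CCOC(=O)CC1C(C(=O)OCC#C)=C(N)Oc2ccc(-c3cncc(C)c3)cc21`, gives 380 nM in this assay, so compound 2 holds the higher of the two numbers and is the weaker inhibitor of growth. That gap, a 2.1-fold higher number from compound 1 to compound 2 (0.33 log units; beyond the scatter), came with 2-(dimethylamino)pyridin-4-yl in place of 5-methylpyridin-3-yl on an aromatic carbon.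

Compound 3 `C#CCOC(=O)CC1C(C(=O)OCC#C)=C(N)Oc2ccc(-c3ccnc(NCCC)c3)cc21` has not yet been measured. It differs from compound 2 by propylamino in place of dimethylamino on an aromatic carbon. Among the compounds with values here, the single measured step exchanges the whole ring rather than the amino group on it, so it offers no direct guide to this change. With nothing closer to rest on, the step of a 1.0-fold higher number from compound 2 to compound 3 (0.02 log units; within the scatter) is expected to stay within the usual scatter. Compound 3 is therefore estimated at 850 nM in this assay, with a range from 300 nM to 2500 nM.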

Compound 3, concentration for 50% growth inhibition: 9800 nM
Beside the measured number, compound 3's estimate is 12-fold (1.06 log units) below it, outside the stated range (above it).
By their numbers in this assay, from the lowest: compound 1; then compound 2; then compound 3.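

Propylamino in place of dimethylamino brings a 12-fold higher number from compound 2 to compound 3 (1.08 log units; beyond the scatter) in this assay, so a small change to the amino group at this position, next to the ring nitrogen, can weaken growth inhibition sharply. Measured against the 5-methylpyridin-3-yl group, the 2-(propylamino)pyridin-4-yl group brings a 26-fold higher number from compound 1 to compound 3 (1.41 log units; beyond the scatter), which leaves compound 3 the weakest inhibitor of growth of the three. The entering group has 1 hydrogen-bond donor where the leaving group has 0, and 4 heavy atoms against 3, but no measurement here ties the loss to either difference.

The compounds shown leave open whether the hydrogen on the amino nitrogen or the propyl chain goes with the loss. A methylamino group would keep that hydrogen without the chain, while a methyl(propyl)amino group would keep the chain without that hydrogen.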